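Methyl Added on a Shared Core: Stability Outlook

A few compounds are considered here, and "the series" means these few. Any claim that something is new, unique, unknown or untested is made for them only; others in the source may bear on it.

Compound 1 `COC(=O)Nc1cc(-c2ccc(OC[C@@](C)(N)CC(C)C)c(C)c2)ccn1`, compound 2 `COC(=O)Nc1cc(-c2ccc(OC[C@@](C)(N)CC(C)C)cn2)ccn1` and compound 3 `COC(=O)Nc1cc(-c2cc(C)c(OC[C@@](C)(N)CC(C)C)cn2)ccn1` share a common core and were compared in an ADME assay on microsomes from liver (Mus musculus) for metabolic stability, read by LC-MS, using NADPH, with a stated time of 10 min, tested at 0.5 uM; on this read-out higher numbers stand for a more stable compound and lower numbers for a less stable compound. Compound 1 gives 75%, compound 2 gives 93%, and compound 3 gives 99%. The difference between the cores of compound 1 and compound 2 is not broken down here. Compound 3 arises from compound 2 by a single change, (methyl in place of hydrogen on an aromatic carbon), and this made a number 6 percentage points higher from compound 2 to compound 3 (within the scatter). Compound 4 `COC(=O)Nc1cc(-c2ccc(OC[C@@](C)(N)CC(C)C)c(C)c2C)ccn1` has not yet been measured; it arises from compound 1 by the same kind of change, (methyl in place of hydrogen on an aromatic carbon). The surroundings differ: in compound 3 the methyl sits on a six-membered aromatic ring with one nitrogen, ortho to the (2-amino-2,4-dimethylpentyl)oxy group, meta to a large group and opposite the ring nitrogen, whereas in compound 4 it sits on a six-membered aromatic ring of carbon only, ortho to a large group, ortho to a methyl group and meta to that oxy group. Compound 4 is expected to show a number 3 percentage points higher from compound 1 to compound 4 (within the scatter), set beside the earlier step because a number 6 percentage points higher from compound 2 to compound 3 (within the scatter) stayed within the scatter. Compound 4 is estimated at 78%, between 60% and 92%.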

Compound 4, percent of the compound remaining: 70%
Estimate against measurement, compound 4: 8 percentage points above; the measured number falls inside the stated range.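

In this assay, putting a methyl in place of a hydrogen on an aromatic carbon of the core of compound 1 gave a number 5 percentage points lower from compound 1 to compound 4 (within the scatter). Set beside the same change on the other core, the two steps cannot be told apart: the same change on two cores in this assay, a number 6 percentage points higher (within the scatter) from compound 2 to compound 3 and a number 5 percentage points lower (within the scatter) from compound 1 to compound 4, 11 percentage points apart, within the scatter of two such steps. Among the compounds shown here, this shows that in these four compounds the methyl change stays within the scatter on both cores, but it does not show that the change is without effect in general, as there are only two steps and the methyl sits in different surroundings in each, so neither the upward nor the downward direction should be read as real.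

The compounds shown leave open whether an ethyl or a methoxy group in place of that methyl would also stay within the scatter. They also leave open whether the methyl change would behave the same way on a third core.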